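The source may report more compounds than this note shows. Statements on the series, on what has been measured and on what is new or still open speak of the compounds shown alone.

Of the compounds shown here, three have been measured in a functional assay on HOS cells (Homo sapiens) for antiproliferative activity, read by sulforhodamine B assay; on this read-out higher numbers stand for weaker inhibition of growth and lower numbers for stronger inhibition of growth.

Compound 1, `CCC[C@@H]1O[C@H](COCc2ccccc2)[C@@H](OCc2ccccc2)[C@H](OCc2ccccc2)[C@@H]1O`, gives > 50000 nM, which is a limit of the assay rather than a number.
Compound 2, `CC(C)C[C@@H]1O[C@H](COCc2ccccc2)[C@@H](OCc2ccccc2)[C@H](OCc2ccccc2)[C@@H]1O`, gives 26300 nM.
Compound 3, `C[C@@H]1O[C@H](COCc2ccccc2)[C@@H](OCc2ccccc2)[C@H](OCc2ccccc2)C1=O`, gives > 50000 nM, again a limit of the assay and not a number.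

Compound 1 and compound 2 share a core and differ in one place: methyl in place of hydrogen on a saturated chain carbon bound to two saturated chain carbons. This change brought an at least 1.9-fold lower number from compound 1 to compound 2 (0.27 log units; that floor lies within the scatter). Since the value of compound 1 is a limit, only a floor for this step is known.

Compound 3 carries a different core, and the difference between the two cores is not broken down here. Compound 4, `CC[C@@H]1O[C@H](COCc2ccccc2)[C@@H](OCc2ccccc2)[C@H](OCc2ccccc2)C1=O`, has not yet been measured. It differs from compound 3 by methyl in place of hydrogen on a saturated chain carbon bound to a saturated ring carbon. This is the same kind of change as that from compound 1 to compound 2, though not the same: in compound 2 the new methyl sits on a saturated chain carbon bound to two saturated chain carbons, whereas in compound 4 it sits on a saturated chain carbon bound to a saturated ring carbon.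

For compound 4 in this assay a step of about the size seen earlier is expected, an at least 1.2-fold lower number from compound 3 to compound 4 (0.09 log units; that floor lies within the scatter), beside the measured at least 1.9-fold lower number from compound 1 to compound 2 (0.27 log units; that floor lies within the scatter). This expectation rests on a single measured pair and on (the limit of > 50000 nM in this assay, at which 2 of the 3 values shown sit), so a limit rather than a number may again be all that comes back. The estimate for compound 4 is 40000 nM, with a range from 15000 nM to 100000 nM.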

Compound 4, concentration for 50% growth inhibition: 4300 nM
For compound 4 the middle estimate is 9.3-fold (0.97 log units) above the measured one; the measured number lies below the stated range.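

In this assay, putting methyl in place of hydrogen on a saturated chain carbon bound to a saturated ring carbon, which turns a methyl into an ethyl, brought an at least 11-fold lower number from compound 3 to compound 4 (1.06 log units; beyond the scatter), a large step. This shows that so small a change can matter a great deal on this core, but it does not show that the change carries over from one core to another with a fixed size, and the new methyl does not sit on the same kind of carbon in the two pairs. Only the second step is clearly beyond the scatter, yet the two cannot be told apart, as each starts from a limit of the assay and gives only a floor for its true size: the same change on two cores in this assay, an at least 1.9-fold lower number (0.27 log units; that floor lies within the scatter) from compound 1 to compound 2 and an at least 11-fold lower number (1.06 log units; beyond the scatter) from compound 3 to compound 4; the limit leaves it open whether they differ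

The compounds shown leave open whether a longer chain on the core of compound 4 would lower the number further or would lose the gain. They also leave open whether a plain carbon chain is needed at all, which an amine or a carboxylic acid at the end of that chain could begin to answer.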